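From methoxy to (trifluoromethyl)sulfanyl on an aromatic carbon

The compounds below may be only part of what the source reports. "The series", "measured", "known", "first", "only" and "open" are said of these compounds alone.

Measured in a functional assay on CCRF-CEM cells (Homo sapiens) for inhibition, read by MTT assay, with a stated time of 72 h; on this read-out higher numbers stand for weaker inhibition and lower numbers for stronger inhibition:
- compound 1 `C=C(Br)C(=O)Nc1cccc(/C=C/C(=O)Nc2ccc(Cl)cc2)c1` gives 460 nM
- compound 2 `C=C(Br)C(=O)Nc1cccc(/C=C/C(=O)NCc2ccc(C)cc2)c1` gives 550 nM
- compound 3 `C=C(Br)C(=O)Nc1cccc(/C=C/C(=O)Nc2ccc(OC)cc2)c1` gives 26 nM

Among these three, compound 3 has the lowest number in this assay. The measurements show an 18-fold lower number from compound 1 to compound 3 (1.25 log units; beyond the scatter) and a 21-fold lower number from compound 2 to compound 3 (1.33 log units; beyond the scatter), so it stands clear of both others. The remaining pair does not separate, with a 1.2-fold higher number from compound 1 to compound 2 (0.08 log units; within the scatter).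

The next compound is compound 4 `C=C(Br)C(=O)Nc1cccc(/C=C/C(=O)Nc2ccc(SC(F)(F)F)cc2)c1`, which carries (trifluoromethyl)sulfanyl in place of methoxy on an aromatic carbon, para to a large group: (trifluoromethyl)sulfanyl in place of methoxy on an aromatic carbon. Among the measured compounds shown here, no measured step involves the entering group, so the expectation rests on analogy. The closest evidence is an 18-fold lower number from compound 1 to compound 3 (1.25 log units; beyond the scatter), a large step at this same place with methoxy entering. The change to compound 4 runs the other way, with methoxy leaving. The step of a 21-fold lower number from compound 2 to compound 3 (1.33 log units; beyond the scatter) is of similar size, but it changes more of the amide side and so bears less directly.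

A large step towards a higher number is expected, probably somewhat smaller than the one seen with chloro, and this is written as a 7.7-fold higher number from compound 3 to compound 4 (0.89 log units; beyond the scatter) in the estimate. For compound 4 the estimated value is 200 nM, with an expected range from 50 nM to 700 nM.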

Compound 4, half-maximal inhibitory concentration: 15300 nM
Beside the measured number, compound 4's estimate is 77-fold (1.88 log units) below it; measured number above the stated range.
By their numbers in this assay, from the lowest: compound 3; then compounds 1 and 2 (each within the scatter of the next); then compound 4.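

In this assay, among the compounds shown here, the aromatic carbon para to a large group now spans a much wider range than the earlier compounds showed, with a 590-fold higher number from compound 3 to compound 4 (2.77 log units; beyond the scatter) in a single exchange of groups, larger than an 18-fold lower number from compound 1 to compound 3 (1.25 log units; beyond the scatter) between methoxy and chloro. (Trifluoromethyl)sulfanyl also stands clearly apart from chloro, with a 33-fold higher number from compound 1 to compound 4 (1.52 log units; beyond the scatter) on the same shared core, so the three groups tried at this place on the anilide series give three separate levels, with methoxy lowest, chloro in the middle and (trifluoromethyl)sulfanyl highest. Nothing in the data shown accounts for the size of this rise or says which feature of the entering group lies behind it.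

The compounds shown leave open where an ethoxy group, a hydroxy group, an amino group or a plain trifluoromethyl group would fall at this place, and so whether methoxy is a special case or one of several groups that give low numbers here. They also leave open whether the same order of groups would hold on the benzyl amide of compound 2 rather than on the anilide series.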